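Methyl in Place of Fluoro on the Aryl Ketone

The source may hold more compounds than are shown below. What is called first, only, known or untested is meant among the compounds shown, and "the series" means these compounds.

Three compounds have been measured in a functional assay on DLA cells (Mus musculus) for cytotoxicity, read by trypan blue exclusion, with a stated time of 48 h; a higher number here means a weaker inhibitor, a lower number a stronger inhibitor:
compound 1 `Cc1ccc(OCC(=O)NNC(=O)c2cc3ccccc3oc2=O)c(C(=O)c2ccccc2Br)c1` gives 10000 nM
compound 2 `Cc1ccc(OCC(=O)NNC(=O)c2cc3ccccc3oc2=O)c(C(=O)c2ccccc2)c1` gives 89100 nM
compound 3 `Cc1ccc(OCC(=O)NNC(=O)c2cc3ccccc3oc2=O)c(C(=O)c2ccc(F)cc2)c1` gives 46100 nM

Compound 3 holds the second highest of these three numbers; compound 2 sits within the scatter of it, while compound 1 lies clearly below it. Compound 4 `Cc1ccc(C(=O)c2cc(C)ccc2OCC(=O)NNC(=O)c2cc3ccccc3oc2=O)cc1` differs from compound 3 by methyl in place of fluoro on an aromatic carbon. Among the compounds with values here, the only measured step on the same ring is a 1.9-fold lower number from compound 2 to compound 3 (0.29 log units; within the scatter), which stayed within the scatter. The step of an 8.9-fold higher number from compound 1 to compound 2 (0.95 log units; beyond the scatter) removes a bromo rather than exchanging a fluoro and bears less directly on the present change. With so little to go on, the author expects no step beyond the scatter in this assay, a 1.2-fold lower number from compound 3 to compound 4 (0.06 log units; within the scatter). Compound 4 is therefore estimated at 40000 nM, within 15000 nM to 120000 nM.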

Compound 4, half-maximal inhibitory concentration: 87300 nM
Estimate against measurement, compound 4: 2.2-fold (0.34 log units) below, within the range that was stated.
By their numbers in this assay, from the lowest: compound 1; then compounds 3, 4 and 2 (each within the scatter of the next).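

At this place on the ring, the exchange of fluoro for methyl leaves the reading in this assay unresolved (a 1.9-fold higher number from compound 3 to compound 4 (0.28 log units; within the scatter)), and adding methyl in place of hydrogen does the same (a 1.0-fold lower number from compound 2 to compound 4 (0.01 log units; within the scatter)), so hydrogen, fluoro and methyl cannot be told apart here. Compound 1, with its 2-bromophenyl group, remains the one that stands apart (an 8.7-fold higher number from compound 1 to compound 4 (0.94 log units; beyond the scatter)). Nothing available explains these results.

Still open, as far as these compounds go, is whether an amine or a carboxylic acid at this place would shift the number, and whether bromo here would match compound 1.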